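The source may hold more compounds than are shown below. What is called first, only, known or untested is meant among the compounds shown, and "the series" means these compounds.

Measured so far:
compound 1 `COC(=O)c1cccc(-c2cnc(C(O)CCc3ccc(-c4ccccc4)cc3)o2)n1`: 9000 nM
compound 2 `O=C(O)c1cc(-c2cnc(C(=O)CCc3ccc(-c4ccccc4)cc3)o2)ccn1`: 50 nM
compound 3 `NC(=O)c1cccc(-c2cnc(C(O)CCc3ccc(-c4ccccc4)cc3)o2)n1`: 20000 nM

In an assay for inhibition of Fatty-acid amide hydrolase 1 (Rattus norvegicus) (a lower number here means a stronger inhibitor, a higher number a weaker inhibitor), compound 2 stands at the lowest number of the three, with compound 1 and compound 3 far higher. Among the measured compounds shown here, the one step that can be read as a single change is a 2.2-fold higher number from compound 1 to compound 3 (0.35 log units; beyond the scatter); compound 2 differs from compound 1 and from compound 3 in more than one place, so the wide gap between them cannot be assigned to any one change.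

Compound 4 `NC(=O)c1ccc(-c2cnc(C(=O)CCc3ccc(-c4ccccc4)cc3)o2)nc1` has not been measured. Relative to compound 2 the change is 5-carbamoylpyridin-2-yl in place of 2-carboxypyridin-4-yl on an aromatic carbon. For the measured compounds named here, no measured step bears on this change directly. Going by the values given here, only the step from compound 1 to compound 3 touches the substituent carried by the pyridine, and there the effect was modest. Compound 4 keeps the carbonyl of compound 2, so the value of compound 2 is the anchor, while the change from a carboxylic acid to a carboxamide together with the altered ring attachment argues for some weakening. The expectation for compound 4 is therefore a modest rise in this assay, a 3.0-fold higher number from compound 2 to compound 4 (0.48 log units; beyond the scatter). The value estimated for compound 4 is 150 nM, within a range from 30 nM to 800 nM.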

Compound 4, inhibition constant: 1.3 nM
For compound 4 the middle estimate is 120-fold (2.06 log units) above the measured one; measured number outside the range, below it.
By their numbers in this assay, from the lowest: compound 4; then compound 2; then compound 1; then compound 3.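

At the aromatic carbon next to the ring oxygen, 5-carbamoylpyridin-2-yl in place of 2-carboxypyridin-4-yl gives a 38-fold lower number from compound 2 to compound 4 (1.59 log units; beyond the scatter) in this assay, so this position responds strongly to the group it carries. The two groups match in their counts of heavy atoms, hydrogen-bond donors and hydrogen-bond acceptors, and both carry no net charge, so these counts do not separate them and the large step goes with how the groups differ in atoms and arrangement. Among the compounds shown here, the only earlier one-place step, a 2.2-fold higher number from compound 1 to compound 3 (0.35 log units; beyond the scatter), is a different change, amino in place of methoxy on a carbonyl carbon, and it is modest beside the new step, while nothing available here explains the size of the new step.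

This single replacement changes the carboxylic acid to a carboxamide and also changes the pyridine attachment, so the step cannot be divided between those differences. Going by these compounds, a carboxylic acid, a nitrile or an amine on the 5-position of a pyridin-2-yl group would help separate them, and the effect of the carbonyl in the chain compared with the alcohol also remains open.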